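This account rests on a few compounds, and the source may have more. Where it says the series, first, only, none or still open, it means among the compounds named here.

Compound 1 `NS(=O)(=O)c1ccc(/C=C/c2ccc(O)c(O)c2)cc1` stands as the weaker of the two measured compounds in a functional assay on HCT-15 cells (Homo sapiens) for inhibition (on this read-out lower numbers stand for stronger inhibition of growth and higher numbers for weaker inhibition of growth), where compound 1 gives 13900 nM. Its only measured companion, compound 2 `COc1cccc(/C=C/c2ccc(S(N)(=O)=O)cc2)c1`, gives 3600 nM in this assay, and the gap between the two lies beyond the usual scatter. Compound 3 `NS(=O)(=O)c1ccc(/C=C/c2ccc(O)cc2)cc1` keeps the core of compound 1 and differs from it in one place: hydrogen in place of hydroxy on an aromatic carbon. Going by the values given here, no measured pair shows what this change does here, so any expectation rests on the two numbers already known, which only say that compound 1 is not the better of the pair. A modest move toward lower numbers, meaning stronger inhibition of growth, is expected for compound 3, written as a 1.7-fold lower number from compound 1 to compound 3 (0.24 log units; within the scatter), though it could well stay within the scatter. Compound 3 is estimated at 8000 nM, with a range from 2500 nM to 25000 nM.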

Compound 3, concentration for 50% growth inhibition: 24600 nM
The estimate for compound 3 lay 3.1-fold (0.49 log units) below the measured number; measured number inside the range.
By their numbers in this assay, from the lowest: compound 2; then compounds 1 and 3 (each within the scatter of the next).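

In this assay the swap of hydrogen for hydroxy, on the aromatic carbon ortho to a hydroxy group and meta to a large group, gives a 1.8-fold higher number from compound 1 to compound 3 (0.25 log units; within the scatter) and so stays inside the usual scatter. Going by these compounds alone, this is the first direct reading of this change, and it shows that, with the other hydroxy group kept, this single hydroxy group makes no difference that can be told apart on this read-out. Nothing measured here offers an explanation for this result.

Going by these compounds, whether an amine or a fluorine atom on this same carbon would give a number beyond the scatter remains open. Also open is whether the remaining hydroxy group matters, since the compounds shown test only one replacement at one position.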